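A few compounds are considered here, and "the series" means these few. Any claim that something is new, unique, unknown or untested is made for them only; others in the source may bear on it.

Measured compounds:
compound 1 `COc1cc2c(cc1CC=C(C)C)/C(=N/NC(N)=O)C[C@@H](c1ccc(O)cc1)O2` with 77%
compound 2 `COc1cc2c(cc1CC=C(C)C)C(=O)C[C@@H](c1ccc(Oc3cccc([N+](=O)[O-])c3)cc1)O2` with 37%

In a functional assay on A549 cells (Homo sapiens) for inhibition, read by sulforhodamine B assay, with a stated time of 48 h, tested at 50 uM (on this read-out higher numbers stand for more inhibition of growth at the one concentration tested and lower numbers for less inhibition of growth), compound 2 stands lowest of the two numbers; its nearest neighbour, compound 1, lies higher by a gap beyond the scatter. Compound 3 `CCCOc1ccc([C@@H]2CC(=O)c3cc(CC=C(C)C)c(OC)cc3O2)cc1` is not yet measured. It differs from compound 2 by propyl in place of 3-nitrophenyl on an oxygen on an aromatic ring. Among the compounds with values here, no step between measured compounds has been recorded, so the size of this change cannot be read from the data. For compound 3 a small rise, within the scatter or just beyond it, is expected, and the step is expected to read a number 8 percentage points higher from compound 2 to compound 3 (within the scatter). Compound 3 is accordingly estimated at 45%, within 20% to 70%.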

Compound 3, percent growth inhibition at one concentration: 43%
Compound 3: middle estimate off by 2 percentage points, on the high side, within the range that was stated.
By their numbers in this assay, from the lowest: compounds 2 and 3 (each within the scatter of the next); then compound 1.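

At this oxygen on an aromatic ring, propyl in place of 3-nitrophenyl reads a number 6 percentage points higher from compound 2 to compound 3 (within the scatter) in this assay. This first step read at the position shows that, at the one concentration tested, the two groups cannot be told apart, although propyl has no ring and no hydrogen-bond acceptors. No further measurement bears on the reading of this step.

From the compounds shown here alone, whether a longer chain, or a propyl chain ending in an amine or a carboxylic acid, would read differently on this oxygen remains open.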